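Chain homologation on the ring nitrogen: cytotoxicity notes

The source may report more compounds than this note shows. Statements on the series, on what has been measured and on what is new or still open speak of the compounds shown alone.

Compound 1 `CCCCCCCNc1cnc(C(=O)NCc2ccccc2)cn1` sits at a limit in an ADME assay on MDCK cells (Canis lupus familiaris) for cytotoxicity, read by microscopy, with a stated time of 6 days (a higher number here means that more compound is tolerated, a lower number that less compound is tolerated), rather than at a number, with > 100000 nM; one of the three entries in this series sits there (the limit of > 100000 nM in this assay, at which 1 of the 3 values shown sits). Compound 2 `CCCCCNc1nccnc1C(=O)NCc1ccccc1` also returns only a limit in this assay, >= 20000 nM (the limit of >= 20000 nM in this assay, at which 1 of the 3 values shown sits). For compound 3 `O=C(NCc1ccccc1)c1cncc(Cl)n1` the entry in this assay reads "not determined" (no result reported). Compound 4 `CCCCCCCCNc1cnc(C(=O)NCc2ccccc2)cn1` has not been measured; it differs from compound 1 by methyl in place of hydrogen on a saturated chain carbon, seven bonds along the chain from a nitrogen on an aromatic ring. For the measured compounds named here, no measured step exists between these compounds, so no size of change is established. The expectation is a step of no size beyond the scatter, with compound 4 likely again reaching only a limit, a number no higher from compound 1 to compound 4 (the limit leaves the size open). Compound 4 is estimated at 100000 nM, within 20000 nM to 300000 nM.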

Compound 4, minimum cytotoxic concentration: >= 20000 nM
Compound 4: a limit, no number; the forecaster's own chance of this, stated with the estimate: 80%; the middle value lies beyond the limit too.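

Compound 1 and compound 4 each return only a limit in this assay, so the step between them cannot be read. The compounds shown leave open at what concentration either compound becomes cytotoxic, and whether chain length matters.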